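Trading One Ring for Another on a Carbonyl Carbon

The compounds below may be only part of what the source reports. "The series", "measured", "known", "first", "only" and "open" are said of these compounds alone.

In an in vivo functional assay on the whole organism for inhibition, with Rattus norvegicus as the target (a lower number here means that less compound is needed, a higher number that more compound is needed for the effect), compound 1 `CCCCc1nc(C)c(CCC(=O)OCC)c(=O)n1Cc1ccc(-c2ccccc2-c2nnn[nH]2)cc1` gives 0.066 mg/kg and compound 2 `CCCCc1nc(C)c(CC(=O)N2CCC[C@H]2C(N)=O)c(=O)n1Cc1ccc(-c2ccccc2-c2nnn[nH]2)cc1` gives 0.023 mg/kg as the lower of the two numbers. Within the data shown here, the only measured step runs a 2.9-fold lower number from compound 1 to compound 2 (0.46 log units; beyond the scatter) and counts as modest. Compound 3 `CCCCc1nc(C)c(CC(=O)N2CCSCC2)c(=O)n1Cc1ccc(-c2ccccc2-c2nnn[nH]2)cc1` has not yet been measured and differs from compound 2 in one group: thiomorpholin-4-yl in place of 2-carbamoylpyrrolidin-1-yl on a carbonyl carbon. Among the measured compounds shown here, the group that leaves is the one that enters in that measured step, so the step is the only guide available. For the measured compounds named here, no measured compound carries thiomorpholin-4-yl. Part of the modest drop may be given back, so a slightly higher number is expected, with the estimated step running a 1.7-fold higher number from compound 2 to compound 3 (0.24 log units; within the scatter) and hardly exceeding the scatter. For compound 3 the estimated value in this assay is 0.04 mg/kg with an expected range from 0.015 mg/kg to 0.11 mg/kg for the measurement.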

Compound 3, dose for half-maximal effect: 0.038 mg/kg
For compound 3 the middle estimate is 1.1-fold (0.02 log units) above the measured one; the measured number falls inside the stated range.
By their numbers in this assay, from the lowest: compounds 2, 3 and 1 (each within the scatter of the next, the first and the last beyond it).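

In this assay, the new step on this carbonyl carbon reads a 1.7-fold higher number from compound 2 to compound 3 (0.22 log units; within the scatter), so compound 2 and compound 3 cannot be told apart. The hydrogen-bond donor and defined stereocentre of 2-carbamoylpyrrolidin-1-yl are therefore not needed to reach this range, as thiomorpholin-4-yl has neither. The other new step reads a 1.7-fold lower number from compound 1 to compound 3 (0.24 log units; within the scatter), so compound 3 cannot be told apart from compound 1 either, even though the step of a 2.9-fold lower number from compound 1 to compound 2 (0.46 log units; beyond the scatter) lies beyond the scatter; no measurement here offers an explanation for any of these results.

From the compounds shown here alone, the role of the ring sulfur remains open, and a morpholin-4-yl group, with oxygen in its place, would test it directly. A plain pyrrolidin-1-yl group on the same carbonyl carbon would likewise separate the contribution of the carbamoyl group from that of the ring.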